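The compounds below may be only part of what the source reports. "The series", "measured", "known", "first", "only" and "open" are said of these compounds alone.

Working notes on the sulfonamide anilide series. Three compounds have been run in a functional assay on HEK293 cells for agonist activity at probable G-protein coupled receptor 27 (Homo sapiens), read by a luciferase reporter and beta-arrestin recruitment, with a stated time of 10 min; a higher number here means a larger maximal response, a lower number a smaller maximal response. Compound 1 `O=C(Nc1ccc(S(=O)(=O)Nc2ccccc2)cc1)c1cc2ccccc2oc1=O` gives 53% in this assay. Compound 2 `Cc1cc(Cl)ccc1C(=O)Nc1ccc(S(=O)(=O)Nc2ccccc2)cc1` gives 123%. Compound 3 `O=C(Nc1ccc(S(=O)(=O)Nc2ccccc2)cc1)c1ccc(C(F)(F)F)cc1F` gives 50%. On these three numbers compound 2 stands highest: compound 1 and compound 3 both lie lower, and both gaps are beyond the usual scatter. Within the data shown here, the two weaker compounds carry acyl groups that differ from compound 2 in more than one place, so no single step between measured compounds is available.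

The next compound, compound 4 `O=C(Nc1ccc(S(=O)(=O)Nc2ccccc2)cc1)c1ccc(Cl)cc1Cl`, is compound 2 with one change: chloro in place of methyl on an aromatic carbon. The group that leaves and the group that enters are each a single heavy atom, and neither adds or removes a hydrogen-bond donor or acceptor. With nothing measured on such a swap in this series, the expectation rests on compound 2 alone.

The step expected is a number 18 percentage points lower from compound 2 to compound 4 (beyond the scatter), small and downward, but possibly none beyond the scatter. Compound 4 is therefore estimated at 105% in this assay, within a range of 65% to 140%.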

Compound 4, largest response reached (Emax), in percent of the reference or control that the assay uses: 100%
Beside the measured number, compound 4's estimate is 5 percentage points above it; the range from low to high includes it.
By their numbers in this assay, from the lowest: compounds 3 and 1 (each within the scatter of the next); then compound 4; then compound 2.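

Among these compounds, this is the first step that can be read at a single place: with chloro in place of methyl on an aromatic carbon, ortho to a large group, this assay shows a number 23 percentage points lower from compound 2 to compound 4 (beyond the scatter). The methyl is therefore not required for a high response at this position, since compound 4 still reaches 100%, although the swap costs a modest amount. No measurement bearing on the origin of this step is available.

The compounds shown leave open how a hydrogen, a methoxy group, an amine or a carboxylic acid on this same carbon would compare with methyl and chloro. They also leave open whether the same swap gives a step of similar size when the other groups on this aromatic ring are different.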